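Lengthening the branched side chain of compound 1

A few compounds are considered here, and "the series" means these few. Any claim that something is new, unique, unknown or untested is made for them only; others in the source may bear on it.

Compound 1, `CCC(CC)Nc1ncnc2c1ncn2C1O[C@H](CO)[C@@H](O)[C@H]1O`: 0.75 nM
Compound 2, `CCCn1c(=O)c2nc(-c3nn[nH]n3)[nH]c2n(CCC)c1=O`: > 10000 nM (a limit of the assay, not a number)
Compound 3, `CCCn1c(=O)c2nc(C(C)(C)C)[nH]c2n(CCC)c1=O`: 31 nM

All three compounds were tested in an assay on cell membranes for binding affinity to adenosine receptor A1 (Cavia porcellus), read by radioligand binding; on this read-out lower numbers stand for stronger inhibition and higher numbers for weaker inhibition. Among the two numbers obtained, compound 1 gives the lowest, and compound 3 the next one at a higher number. For compound 2 the assay reports only a limit, (the limit of > 10000 nM in this assay, at which 1 of the 3 values shown sits), so no number is known for it.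

Going by the values given here, the only step between two measured compounds that differ in one place is an at least 320-fold lower number from compound 2 to compound 3 (2.50 log units; beyond the scatter), and it sits on a core different from that of compound 1, so it does not bear on the change considered here.

Compound 4, `CCCC(CCC)Nc1ncnc2c1ncn2C1O[C@H](CO)[C@@H](O)[C@H]1O`, is not yet measured. It differs from compound 1 by 1-propylbutyl in place of pentan-3-yl on a nitrogen on an aromatic ring. Among the compounds with values here, no measured step touches this position, so the expectation for compound 4 rests on compound 1 alone, with a step expected to stay within or near the scatter and a slightly higher number not ruled out. Compound 4 is therefore expected to give 1.5 nM, between 0.4 nM and 6 nM, an estimated step of a 2.0-fold higher number from compound 1 to compound 4 (0.30 log units; within the scatter).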

Compound 4, inhibition constant: 3.3 nM
For compound 4 the middle estimate is 2.2-fold (0.34 log units) below the measured one; low and high end bracket the measured number.
By their numbers in this assay, from the lowest: compound 1; then compound 4; then compound 3. At a limit, above all of these: compound 2.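

Going by these compounds alone, this is the first step that can be read on the core of compound 1, and it shows that the number at this position responds to the length of the branched chain: in this assay, moving from pentan-3-yl to 1-propylbutyl on the nitrogen weakens inhibition modestly but beyond the scatter (a 4.4-fold higher number from compound 1 to compound 4 (0.64 log units; beyond the scatter)). The larger group, with 7 heavy atoms against 5, is thus tolerated at a measurable cost, and binding is weakened rather than lost. Nothing measured here explains this step.

On these data alone, it remains open whether a smaller or ring-shaped group, such as ethyl or cyclopentyl, would give a lower number than pentan-3-yl. Also unsettled is whether a still longer branched chain would continue to raise the number or whether a hydroxyl group on the chain would change the trend.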